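The source may report more compounds than this note shows. Statements on the series, on what has been measured and on what is new or still open speak of the compounds shown alone.

Measured in a functional assay on HL-60 cells (Homo sapiens) for antiproliferative activity, with a stated time of 72 h; on this read-out higher numbers stand for weaker inhibition and lower numbers for stronger inhibition:
- Compound 1 `OC[C@H]1O[C@@H](n2cnc3c(NCc4ccc(F)cc4)ncnc32)[C@H](O)[C@@H]1O`: 1200 nM
- Compound 2 `COc1cccc(CNc2ncnc3c2ncn3[C@@H]2O[C@H](CO)[C@@H](O)[C@H]2O)c1`: 4900 nM
- Compound 3 `COc1cccc(CNc2ncnc3c2ncn3[C@@H]2O[C@H](CO)[C@@H](O)[C@H]2O)c1OC`: > 166000 nM, a limit and not a number

Compound 3 is the weakest of the three, and its reading is only a limit. Compound 4 `OC[C@H]1O[C@@H](n2cnc3c(NCc4ccc(F)c(Cl)c4)ncnc32)[C@H](O)[C@@H]1O` differs from it as follows: 3-chloro-4-fluorophenyl in place of 2,3-dimethoxyphenyl on a saturated chain carbon bound to a nitrogen on an aromatic ring. In words, 3-chloro-4-fluorophenyl takes the place of 2,3-dimethoxyphenyl on a saturated chain carbon bound to a nitrogen on an aromatic ring.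

Two large steps bear on this change: an at least 130-fold higher number from compound 1 to compound 3 (2.14 log units; beyond the scatter) and an at least 33-fold higher number from compound 2 to compound 3 (1.52 log units; beyond the scatter). The second comes from adding one methoxy. Among the compounds with values here, a modest step, a 4.1-fold higher number from compound 1 to compound 2 (0.61 log units; beyond the scatter), shows that the single methoxy of compound 2 costs far less. The entering group has no methoxy and keeps the fluorine of compound 1, so the reading is expected to return towards that of compound 1, at 1200 nM. Within the data shown here, no measured compound carries chlorine, which widens the uncertainty.

A large fall is expected, with an estimated at least 110-fold lower number from compound 3 to compound 4 (2.04 log units; beyond the scatter). For compound 4 the estimated value is 1500 nM, with an expected range of 400 nM to 6000 nM.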

Compound 4, half-maximal inhibitory concentration: 3500 nM
For compound 4 the middle estimate is 2.3-fold (0.37 log units) below the measured one, within the range that was stated.
By their numbers in this assay, from the lowest: compound 1; then compounds 4 and 2 (each within the scatter of the next). At a limit, above all of these: compound 3.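

In this assay, adding chloro to the phenyl ring of compound 1 costs little, with a 2.9-fold higher number from compound 1 to compound 4 (0.46 log units; beyond the scatter), and swapping 3-methoxyphenyl for 3-chloro-4-fluorophenyl gives a 1.4-fold lower number from compound 2 to compound 4 (0.15 log units; within the scatter), so these two different groups on this saturated chain carbon read alike. The change away from 2,3-dimethoxyphenyl gives an at least 47-fold lower number from compound 3 to compound 4 (1.67 log units; beyond the scatter), which shows that two substituents on this phenyl ring do not in themselves bring the large loss. The reading of compound 3 is a limit and not a number, so that step is only a bound: the limit of > 166000 nM in this assay, at which 1 of the 4 values shown sits.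

From the compounds shown here alone, it remains open whether the loss in compound 3 is specific to its pair of methoxy groups. Going by these compounds, it also remains open how an amine or a carboxylic acid on this phenyl ring would read.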